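This account rests on a few compounds, and the source may have more. Where it says the series, first, only, none or still open, it means among the compounds named here.

Compound 1 `CC(C)=CCc1cc(C(=O)Nc2cc3ccc(OCCCN4CCCCC4)c(C)c3oc2=O)ccc1O` and compound 3 `CC(C)=CCc1cc(C(=O)Nc2cc3ccc(OCCCN[C@H](C)c4ccccc4)c(C)c3oc2=O)ccc1O` share one core and differ in a single group on the side chain. In a functional assay on SK-BR-3 cells (Homo sapiens) for antiproliferative activity (a higher number here means a weaker inhibitor, a lower number a stronger inhibitor), compound 1 is reported only as a limit, > 50000 nM, so no exact number is known for it. Compound 2 `CC(C)=CCc1cc(C(=O)Nc2cc3ccc(OCCCNCc4ccccc4)c(C)c3oc2=O)ccc1O`, which carries a benzylamino group at the same spot, gives 470 nM in this assay. Among the measured compounds shown here, the step of an at least 100-fold lower number from compound 1 to compound 2 (2.02 log units; beyond the scatter) is the one measured change that bears on compound 3; its size rests on (the limit of > 50000 nM in this assay, at which 1 of the 2 values shown sits), which is why it reads as a lower bound rather than an exact amount. The change to compound 3 is closely related: (1-phenylethyl)amino in place of piperidin-1-yl on a saturated chain carbon, three bonds along the chain from an oxygen on an aromatic ring. The entering group is a benzylamino group carrying a methyl and a defined stereocentre, so a step of about the size seen from compound 1 to compound 2 is expected, in the direction of a stronger inhibitor. The step from compound 1 to compound 3 is therefore estimated as an at least 83-fold lower number from compound 1 to compound 3 (1.92 log units; beyond the scatter). Compound 3 is expected to give 600 nM, within a range from 150 nM to 2500 nM.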

Compound 3, half-maximal inhibitory concentration: 1000 nM
Compound 3: the middle estimate sits 1.7-fold (0.22 log units) below what was measured; the range from low to high includes it.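

In this assay, (1-phenylethyl)amino in place of piperidin-1-yl gives an at least 50-fold lower number from compound 1 to compound 3 (1.69 log units; beyond the scatter), so a large step at this position now appears with two entering groups, benzylamino in compound 2 and (1-phenylethyl)amino in compound 3, and not with just one. The true size of this step stays unknown, and the figure is only a lower bound, because compound 1 is reported as a limit and not as a number: the limit of > 50000 nM in this assay, at which 1 of the 3 values shown sits.

The new pair that involves no limit gives a more exact reading: methyl in place of hydrogen on the saturated chain carbon bound to an amine nitrogen and an aromatic carbon gives a 2.1-fold higher number from compound 2 to compound 3 (0.33 log units; beyond the scatter), a modest step that keeps most of the large gain seen over compound 1.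

The compounds shown leave open whether the amine hydrogen or the aromatic ring of the entering groups goes with that gain, which an N-methyl-N-benzylamino group or a cyclohexylamino group would separate. They also leave open how the opposite mirror-image form of the (1-phenylethyl)amino group compares with the form in compound 3.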